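Ether variation on the shared core: compound 4 expected

A few compounds are considered here, and "the series" means these few. Any claim that something is new, unique, unknown or untested is made for them only; others in the source may bear on it.

Measured so far in an assay on cells for inhibition of MAP kinase-interacting serine/threonine-protein kinase 1 (Homo sapiens), read by mobility shift assay, with stated times of 10 min and 60 min, in the presence of a further agent that is not named here; a lower number here means a stronger inhibitor, a higher number a weaker inhibitor:
compound 1 `Cc1cc(-c2cccnc2)ccc1C(N)=O` gives 22000 nM
compound 2 `NC(=O)c1ccc(-c2cccnc2)cc1OC1CCNC1` gives 1900 nM
compound 3 `NC(=O)c1ccc(-c2cccnc2)cc1OC1CCCCC1` gives 1500 nM

Compound 3 holds the lowest number of the three. Its gap to compound 2 is within the scatter (a 1.3-fold lower number from compound 2 to compound 3 (0.10 log units; within the scatter)), so the two are not separated, whereas compound 1 stands clearly apart (a 15-fold lower number from compound 1 to compound 3 (1.17 log units; beyond the scatter)).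

Compound 4 `COc1cc(-c2cccnc2)ccc1C(N)=O` differs from compound 3 by methyl in place of cyclohexyl on an oxygen on an aromatic ring. Within the data shown here, two measured steps bear on it. From compound 1, both oxy rings brought large drops: a 12-fold lower number from compound 1 to compound 2 (1.06 log units; beyond the scatter) and a 15-fold lower number from compound 1 to compound 3 (1.17 log units; beyond the scatter). Between the two rings the difference was small (a 1.3-fold lower number from compound 2 to compound 3 (0.10 log units; within the scatter)). Among the measured compounds shown here, no measured pair isolates the methoxy itself, so it is unknown how much of the gain over compound 1 rests on the oxygen and how much on the ring attached to it. Compound 4 keeps the oxygen but carries only a methyl on it, so a number between compound 3 and compound 1 is expected, most likely nearer compound 3 than compound 1 is. The step is expected to read a 5.3-fold higher number from compound 3 to compound 4 (0.73 log units; beyond the scatter). For compound 4 the estimate is 8000 nM, with a range from 3000 nM to 25000 nM.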

Compound 4, half-maximal inhibitory concentration: 2800 nM
Estimate against measurement, compound 4: 2.9-fold (0.46 log units) above, outside the stated range (below it).
By their numbers in this assay, from the lowest: compounds 3, 2 and 4 (each within the scatter of the next); then compound 1.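

In this assay, methyl on the oxygen is not separated from either ring: a 1.9-fold higher number from compound 3 to compound 4 (0.27 log units; within the scatter) and a 1.5-fold higher number from compound 2 to compound 4 (0.17 log units; within the scatter) both lie within the scatter, so among compounds 2, 3 and 4 the change from a one-carbon group to a pyrrolidin-3-yl or cyclohexyl ring does not register. Among these compounds, the single change of methoxy in place of methyl on an aromatic carbon still gives a step beyond the scatter, a 7.9-fold lower number from compound 1 to compound 4 (0.90 log units; beyond the scatter), so the ring is not required for a clear separation from compound 1, and the smallest ether on this oxygen already does so. Nothing measured in this set accounts for that step.

From the compounds shown here alone, whether the oxygen itself is what matters remains open, since a hydroxyl, an amine or a fluorine at this aromatic carbon would be needed to tell the oxygen from other atoms placed there. Also open, going by these compounds, is whether any group on the oxygen moves the number away from the level shared by compounds 2, 3 and 4, for example a longer chain ending in a carboxylic acid or a primary amine.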